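Three limits and one change repeated on a second core

The source may hold more compounds than are shown below. What is called first, only, known or untested is meant among the compounds shown, and "the series" means these compounds.

Compound 1 `Cc1nc(N)c2c(-c3ccccc3)cn([C@@H]3O[C@H](CO)[C@@H](O)[C@H]3O)c2n1` is the parent of this small set. In a functional assay on K562 cells (Homo sapiens), read by MTT assay, with a stated time of 72 h (on this read-out higher numbers stand for weaker inhibition and lower numbers for stronger inhibition), compound 1 gives only a limit, > 20000 nM. Compound 2 `Cc1nc(N)c2c(-c3cccs3)cn([C@@H]3O[C@H](CO)[C@@H](O)[C@H]3O)c2n1` carries thiophen-2-yl in place of phenyl on an aromatic carbon. In this assay compound 2 likewise returns only a limit, > 20000 nM. Compound 3 `Nc1nc(N)c2c(-c3ccccc3)cn([C@@H]3O[C@H](CO)[C@@H](O)[C@H]3O)c2n1` differs from compound 1 in its core by amino in place of methyl on an aromatic carbon. In this assay compound 3 again returns only a limit, > 20000 nM. Neither a step that the two limits leave unreadable from compound 1 to compound 2 nor a step that the two limits leave unreadable from compound 1 to compound 3 can be sized, because the limit of > 20000 nM in this assay, at which 3 of the 3 values shown sit, leaves no readable number on either side of the step.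

Compound 4 `Nc1nc(N)c2c(-c3cccs3)cn([C@@H]3O[C@H](CO)[C@@H](O)[C@H]3O)c2n1` has not yet been measured. It stands to compound 3 exactly as compound 2 stands to compound 1: thiophen-2-yl in place of phenyl on an aromatic carbon. The place of the change is described in the same words for both pairs, so this is the same change made on a second core, the two cores differing only in the amino in place of methyl noted above. Since nothing in the set rises above the limit, the step from compound 3 to compound 4 is expected to be a step that the limit leaves unreadable from compound 3 to compound 4, an expectation that rests on the unreadable a step that the two limits leave unreadable from compound 1 to compound 2 on the parent core and on the limit shown for compound 3, > 20000 nM. Compound 4 is therefore expected to give about 35000 nM, somewhere from 15000 nM to 150000 nM, and most probably the assay will once more report only a limit.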

Compound 4, half-maximal inhibitory concentration: > 20000 nM
Compound 4 was reported as a limit; the forecaster's own chance of this, stated with the estimate: 85%; the middle value lies beyond the limit too.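

In this assay compound 4 returns only a limit, > 20000 nM. No new step can be read from compound 3 or compound 2 to compound 4, because no readable number lies on either side: the limit of > 20000 nM in this assay, at which 4 of the 4 values shown sit. The compounds shown leave open whether thiophen-2-yl in place of phenyl, or amino in place of methyl, changes inhibition at all on either core.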